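Adding a second methoxy to compound 3

This account rests on a few compounds, and the source may have more. Where it says the series, first, only, none or still open, it means among the compounds named here.

Three compounds have measured values in a functional assay on MCF7 cells (Homo sapiens) for antiproliferative activity, read by sulforhodamine B assay, with a stated time of 48 h; on this read-out lower numbers stand for stronger inhibition and higher numbers for weaker inhibition. Compound 1 `O=C(/C=C/c1cccs1)c1ccccc1-c1ccc(F)cc1` gives 9500 nM. Compound 2 `COc1ccc(/C=C/C(=O)c2ccccc2-c2cccnc2)cc1` gives 830 nM. Compound 3 `COc1ccc(C(=O)/C=C/c2ccccc2-c2ccc(F)nc2)cc1` gives 13000 nM, a value within the scatter of compound 1 and clearly weaker than that of compound 2.

Compound 4 `COc1ccc(C(=O)/C=C/c2ccccc2-c2ccc(F)nc2)cc1OC` departs from compound 3 by one change: methoxy in place of hydrogen on an aromatic carbon. This is methoxy in place of hydrogen on an aromatic carbon, ortho to a methoxy group and meta to a large group.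

Among the compounds with values here, no measured pair in this set differs in one place, so the effect of this change cannot be read directly from the data. Both compounds with a methoxy group are informative only as a caution: compound 3 stands at 13000 nM and compound 2 at 830 nM, so carrying a methoxy group does not by itself fix the number, and those two differ elsewhere as well.

With no direct evidence for a large shift, the expected result is a 1.4-fold lower number from compound 3 to compound 4 (0.16 log units; within the scatter), a small move toward lower numbers that stays within the scatter. For compound 4 the estimated value is 9000 nM, with an expected range from 3000 nM to 25000 nM.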

Compound 4, half-maximal inhibitory concentration: 41000 nM
For compound 4 the middle estimate is 4.6-fold (0.66 log units) below the measured one; measured number above the stated range.
By their numbers in this assay, from the lowest: compound 2; then compounds 1 and 3 (each within the scatter of the next); then compound 4.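

In this assay, within the data shown here, methoxy in place of hydrogen on an aromatic carbon, ortho to a methoxy group and meta to a large group, gives a 3.2-fold higher number from compound 3 to compound 4 (0.50 log units; beyond the scatter) and so provides the first direct reading of a single change. The step is modest but beyond the scatter, which shows that this position does not take the added methoxy without a loss of antiproliferative activity, at least on the core of compound 3. The data shown offer no measurement that accounts for this loss.

Open, going by these compounds, is whether the loss belongs to methoxy itself or to any group at this carbon; a hydroxyl, a fluorine or an amine at the same place would separate these cases, and a longer ether chain such as ethoxy would test the size of the group entered. Also open, on these data alone, is whether the same step would appear on the core of compound 2, which gives 830 nM and rests on a different arrangement from that of compound 3.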